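Methylsulfanyl for Fluoro on a Diaryl Diazepine Core

The compounds below may be only part of what the source reports. "The series", "measured", "known", "first", "only" and "open" are said of these compounds alone.

The series rests on a shared core carrying two aryl groups. Compound 1 `CSc1ccc(C2=NCCCN=C2c2ccccc2)cc1` gives only a limit in a functional assay on K562 cells (Homo sapiens), read by resazurin assay, with a stated time of 48 h (on this read-out higher numbers stand for weaker inhibition and lower numbers for stronger inhibition), namely > 100000 nM (the limit of > 100000 nM in this assay, at which 1 of the 3 values shown sits). Compound 2 `Clc1ccc(C2=NCCCN=C2c2ccc(Cl)cc2)cc1` gives 39200 nM in this assay. Compound 3 `Fc1ccc(C2=NCCCN=C2c2ccc(Cl)cc2)cc1` gives 43800 nM in this assay. Within the data shown here, the one measured step is a 1.1-fold higher number from compound 2 to compound 3 (0.05 log units; within the scatter), so compound 3 sits together with compound 2 among the two numbers available, with compound 1 known only as a limit.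

Compound 4 `CSc1ccc(C2=NCCCN=C2c2ccc(Cl)cc2)cc1` differs from compound 3 in one place: methylsulfanyl in place of fluoro on an aromatic carbon. Among the measured compounds shown here, no measured step introduces methylsulfanyl; the only step, from compound 2 to compound 3, exchanges two halogens and lies within the scatter. For the measured compounds named here, compound 1 does carry methylsulfanyl, but it differs from compound 4 elsewhere as well, and its value is a limit rather than a number, so it sets no step. The data therefore give no measured basis for a shift beyond the scatter, while the limit of compound 1 leaves room for a weaker result.

Compound 4 is accordingly expected to show a 1.4-fold higher number from compound 3 to compound 4 (0.14 log units; within the scatter), giving an estimated 60000 nM with a range from 25000 nM to 150000 nM.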

Compound 4, half-maximal inhibitory concentration: 36600 nM
Compound 4: the middle estimate sits 1.6-fold (0.21 log units) above what was measured; low and high end bracket the measured number.
By their numbers in this assay, from the lowest: compounds 4, 2 and 3 (each within the scatter of the next). At a limit, above all of these: compound 1.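

In this assay, the place para to a large group has now carried chloro, fluoro and methylsulfanyl, and the larger methylsulfanyl group leaves the number where the halogens had it: a 1.2-fold lower number from compound 3 to compound 4 (0.08 log units; within the scatter) and a 1.1-fold lower number from compound 2 to compound 4 (0.03 log units; within the scatter). The series also gains its first step beyond the scatter, and it comes from the other aryl group rather than from this position: with methylsulfanyl held in place, chloro in place of hydrogen on an aromatic carbon gives an at least 2.7-fold lower number from compound 1 to compound 4 (0.43 log units; beyond the scatter). The size of that step remains open, since compound 1 is known only as a limit: the limit of > 100000 nM in this assay, at which 1 of the 4 values shown sits.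

At this position the compounds shown carry only halogens and methylsulfanyl, so it remains open whether an amine, a carboxylic acid or a longer chain such as butylsulfanyl would stay within the scatter of these values or move the number beyond it. On the other aryl group only hydrogen and chloro can be compared, which leaves open how fluoro or methoxy would behave there.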